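Lipophilicity notes: ring substituent swap on the pyrazole nitrogen

A few compounds are considered here, and "the series" means these few. Any claim that something is new, unique, unknown or untested is made for them only; others in the source may bear on it.

Measured compounds in a physicochemical assay for lipophilicity, at pH 7.4; on this read-out lower numbers stand for lower lipophilicity and higher numbers for higher lipophilicity:
compound 1 `CCc1c2nc(-c3cc(S(=O)(=O)N4CCN(CC)CC4)cnc3OCCOC)[nH]c(=O)c2nn1CC1CC1` gives 1
compound 2 `CCc1c2nc(-c3cc(S(=O)(=O)N4CCN(CC)CC4)cnc3OCC(C)C)[nH]c(=O)c2nn1CCOC` gives 2.9
compound 3 `CCc1c2nc(-c3cc(S(=O)(=O)N4CCN(CC)CC4)cnc3OCCOC)[nH]c(=O)c2nn1CCOC` gives 1.4

Compound 3 sits second highest of the three, above compound 1 by a number 0.40 log units higher from compound 1 to compound 3 (beyond the scatter) and far below compound 2 by a number 1.50 log units lower from compound 2 to compound 3 (beyond the scatter).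

Compound 4 `CCc1c2nc(-c3cc(S(=O)(=O)N4CCN(CC)CC4)cnc3OCCOC)[nH]c(=O)c2nn1C1CCC1` has not been measured in this assay. Its change from compound 3 is cyclobutyl in place of 2-methoxyethyl on an aromatic nitrogen. The step most directly relevant is the one at the same place: compound 1 to compound 3 exchanged a cyclopropyl for a methoxymethyl on the chain carbon bound to the aromatic nitrogen, and this assay rose by a number 0.40 log units higher from compound 1 to compound 3 (beyond the scatter), so a small carbocycle there sat lower than the ether chain. Compound 2 to compound 3 runs the other way on the ring oxygen, where methoxymethyl replacing isopropyl dropped the read-out by a number 1.50 log units lower from compound 2 to compound 3 (beyond the scatter). The two steps pull in opposite directions; the nearer comparison argues for little change, the other for a rise when an ether is replaced by hydrocarbon. Weighing both, compound 4 is expected to show a modest rise, a number 0.40 log units higher from compound 3 to compound 4 (beyond the scatter), with an estimate of 1.8 and a range from 1.1 to 2.6.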

Compound 4, distribution coefficient: 1
The estimate for compound 4 lay 0.80 log units above the measured number; measured number outside the range, below it.
By their numbers in this assay, from the lowest: compounds 1 and 4 (each within the scatter of the next); then compound 3; then compound 2.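

On the aromatic nitrogen, in this assay, cyclobutyl in place of 2-methoxyethyl gives a number 0.40 log units lower from compound 3 to compound 4 (beyond the scatter), and the second hydrocarbon pairing at this nitrogen gives no change at the digits printed from compound 1 to compound 4 (within the scatter), so cyclobutyl, bound directly, and cyclopropylmethyl, bound through a chain carbon, are not told apart by this read-out. Compounds 1, 3 and 4 therefore show the 2-methoxyethyl group reading above both carbocyclic groups at this nitrogen, while the ether-to-hydrocarbon relation on the chain at the ring oxygen goes against this, with a number 1.50 log units lower from compound 2 to compound 3 (beyond the scatter) on moving to the ether there. Nothing at hand accounts for this difference between the two places.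

The compounds shown leave open how an open hydrocarbon chain such as n-propyl, a hydroxyethyl group or an aminoethyl group would read on this aromatic nitrogen, and whether a larger carbocycle such as cyclohexyl would stay level with cyclobutyl. Also open, on these data alone, is whether the step from 2-methoxyethyl to cyclobutyl keeps its direction and size when the isobutyl ether of compound 2 replaces the 2-methoxyethyl ether on the ring oxygen.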